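Triazole ester series on the shared core: ring substituent change

This account rests on a few compounds, and the source may have more. Where it says the series, first, only, none or still open, it means among the compounds named here.

Measured compounds in a functional assay on DU-145 cells (Homo sapiens) for antiproliferative activity, read by MTT assay, with a stated time of 48 h; on this read-out higher numbers stand for weaker inhibition and lower numbers for stronger inhibition:
- compound 1 `C/C(=C\CC/C(C)=C/CC[C@@H]1[C@@]2(C)CCC(=O)C(C)(C)[C@H]2CC[C@@]1(C)O)CC/C=C(\C)C(=O)OCc1cn(-c2ccccc2C(F)(F)F)nn1`, reported only as an assay limit, > 150000 nM
- compound 2 `C/C(=C\CC/C(C)=C/CC[C@@H]1[C@@]2(C)CCC(=O)C(C)(C)[C@H]2CC[C@@]1(C)O)CC/C=C(\C)C(=O)OCc1cn(-c2ccccc2[N+](=O)[O-])nn1`, reported only as an assay limit, > 150000 nM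
- compound 3 `COc1ccc(-n2cc(COC(=O)/C(C)=C/CC/C(C)=C/CC/C(C)=C/CC[C@@H]3[C@@]4(C)CCC(=O)C(C)(C)[C@H]4CC[C@@]3(C)O)nn2)cc1`, reported as a number, 135000 nM

Compound 2 stands at the limit of this assay, with no number beneath it; one other value in the set sits at the same limit (the limit of > 150000 nM in this assay, at which 2 of the 3 values shown sit). The step that the two limits leave unreadable from compound 1 to compound 2 is therefore unreadable. The step of an at least 1.1-fold lower number from compound 2 to compound 3 (0.04 log units; that floor lies within the scatter) only says the number for compound 3 is at least slightly lower, a floor within the scatter; likewise an at least 1.1-fold lower number from compound 1 to compound 3 (0.04 log units; that floor lies within the scatter).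

Compound 4 `C/C(=C\CC/C(C)=C/CC[C@@H]1[C@@]2(C)CCC(=O)C(C)(C)[C@H]2CC[C@@]1(C)O)CC/C=C(\C)C(=O)OCc1cn(-c2cccc(O)c2)nn1` is the next compound in this assay. The change is 3-hydroxyphenyl in place of 2-nitrophenyl on an aromatic nitrogen. For the measured compounds named here, only the steps to compound 3 bear on it, and neither shows a change beyond the scatter, so no step beyond the scatter is expected in this assay. Compound 4 is expected near the limit, estimated at 150000 nM, range 80000 nM to 300000 nM, which means an expected step of a number no higher from compound 2 to compound 4 (the limit leaves the size open).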

Compound 4, half-maximal inhibitory concentration: 28400 nM
The estimate for compound 4 lay 5.3-fold (0.72 log units) above the measured number, outside the stated range (below it).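

In this assay, for the compounds shown here, the group on the aromatic nitrogen can move the number beyond the scatter, which the earlier compounds did not show: 3-hydroxyphenyl in place of 4-methoxyphenyl gives a 4.8-fold lower number from compound 3 to compound 4 (0.68 log units; beyond the scatter). The same position also gives an at least 5.2-fold lower number from compound 2 to compound 4 (0.72 log units; beyond the scatter) and an at least 5.2-fold lower number from compound 1 to compound 4 (0.72 log units; beyond the scatter). These last two steps are floors only, because compound 1 and compound 2 each stand at a limit and not at a number: the limit of > 150000 nM in this assay, at which 2 of the 4 values shown sit.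

As far as these compounds go, whether the step depends on the hydroxyl itself stays open; an amine or a carboxylic acid at the same place on the phenyl ring would test this. Also open is how much the place of the hydroxyl on the ring matters, as 3-hydroxyphenyl is the only hydroxyl-bearing group among the compounds shown.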